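The source may hold more compounds than are shown below. What is called first, only, known or untested is meant among the compounds shown, and "the series" means these compounds.

Compound 3 `CN(C)C(=O)N(Cc1ccco1)Cc1cc([N+](=O)[O-])ccc1O` is one of three compounds built on the same core. In a functional assay on K562 cells (Homo sapiens) for antiproliferative activity, read by MTT assay, with a stated time of 48 h (a higher number here means a weaker inhibitor, a lower number a stronger inhibitor), compound 3 gives 28600 nM. Compound 2 `CN(C)C(=O)N(Cc1ccco1)Cc1cc(Cl)ccc1O` gives 28600 nM in this assay, and compound 1 `CN(C)C(=O)N(Cc1cccc([N+](=O)[O-])c1)Cc1ccco1` gives 35400 nM. Compound 3 is thus level with compound 2 at the digits shown, and the step of a 1.2-fold lower number from compound 1 to compound 3 (0.09 log units; within the scatter) places compound 1 within the scatter as well, so the three numbers cannot be told apart.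

Compound 4 `CN(C)C(=O)N(Cc1ccco1)Cc1cc(Br)ccc1O` differs from compound 3 by bromo in place of nitro on an aromatic carbon. The measured step that bears on this change is no change at the digits printed from compound 2 to compound 3 (within the scatter), in which nitro took the place of chloro at the same position and the number did not move. The other step, a 1.2-fold lower number from compound 1 to compound 3 (0.09 log units; within the scatter), concerns the hydroxy and says less about the present swap. Because no change at the digits printed from compound 2 to compound 3 (within the scatter) stayed within the scatter, no step beyond the scatter in either direction is expected in this assay when bromo takes the place of nitro. Compound 4 is therefore estimated at 29000 nM in this assay, with a range from 14000 nM to 60000 nM. The step this estimate implies, a 1.0-fold higher number from compound 3 to compound 4 (0.01 log units; within the scatter), is expected to lie within the scatter.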

Compound 4, half-maximal inhibitory concentration: 40500 nM
The estimate for compound 4 lay 1.4-fold (0.15 log units) below the measured number; the measured number falls inside the stated range.
By their numbers in this assay, from the lowest: compounds 2, 3, 1 and 4 (each within the scatter of the next).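

At the aromatic carbon para to a hydroxy group, the earlier compounds had shown only that nitro and chloro could not be told apart, and bromo now joins them in this assay, with a 1.4-fold higher number from compound 3 to compound 4 (0.15 log units; within the scatter) and a 1.4-fold higher number from compound 2 to compound 4 (0.15 log units; within the scatter). The position has thus carried three different groups without a step beyond the scatter, even though the change from nitro to bromo replaces a group of several heavy atoms that has hydrogen-bond acceptors with a single bromine atom that has none. The compounds therefore show no preference among these three groups at this position, and no evidence is available to explain that outcome.

It remains open whether an amine or a carboxylic acid at this position would produce a step beyond the scatter, since the groups shown there are limited to nitro, chloro and bromo. From the compounds shown here alone, it is also open whether a longer chain in place of the hydroxy group, or a change elsewhere on the shared core, would separate these compounds in this assay.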